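Phenoxy in Place of Hydrogen: Compound 2 to Compound 4

The compounds below may be only part of what the source reports. "The series", "measured", "known", "first", "only" and "open" are said of these compounds alone.

Compound 2 `O=C(O)CCc1ccc(NCc2ccccc2)cc1` stands at the higher end of the two numbers read in a functional assay for agonist activity at Free fatty acid receptor 1 (Homo sapiens); a lower number here means that less compound is needed, a higher number that more compound is needed for the effect: compound 2 gives 7940 nM, while compound 1 `O=C(O)CCc1ccc(NCc2ccc(Cl)s2)cc1` gives 2000 nM. The step of a 4.0-fold higher number from compound 1 to compound 2 (0.60 log units; beyond the scatter) is a modest rise. Compound 3 `CS(=O)(=O)Nc1cccc(CNc2ccc(CCC(=O)O)cc2)c1` reaches only a limit of the assay in this assay, at < 31700 nM. The step that the limit leaves unreadable from compound 2 to compound 3 therefore cannot be sized.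

Compound 4 `O=C(O)CCc1ccc(NCc2ccc(Oc3ccccc3)cc2)cc1` differs from compound 2 by phenoxy in place of hydrogen on an aromatic carbon, placed para to a large group. For the measured compounds named here, two measured steps touch this change: a 4.0-fold higher number from compound 1 to compound 2 (0.60 log units; beyond the scatter) shows that exchanging 5-chlorothiophen-2-yl for plain phenyl raised the number, and a step that the limit leaves unreadable from compound 2 to compound 3 tells nothing readable about a substituent on that phenyl. On that basis a lower number than that of compound 2 is expected for compound 4, the expected step being a 9.9-fold lower number from compound 2 to compound 4 (1.00 log units; beyond the scatter). Compound 4 is thus estimated at 800 nM in this assay, with a range from 150 nM to 4000 nM.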

Compound 4, half-maximal effective concentration: 195 nM
The estimate for compound 4 lay 4.1-fold (0.61 log units) above the measured number; measured number inside the range.
By their numbers in this assay, from the lowest: compound 4; then compound 1; then compound 2.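

In this assay, for the compounds shown here, the step of a 41-fold lower number from compound 2 to compound 4 (1.61 log units; beyond the scatter) is the first readable effect of a substituent on the phenyl ring of compound 2, and it is a large one. The earlier substituent on that ring gave no such reading, because compound 3 stands only at a limit of the assay: the limit of < 31700 nM in this assay, at which 1 of the 4 values shown sits. The new result therefore shows that this ring can carry a further six-membered aromatic ring, held through oxygen at the place para to a large group, and that the number then falls well beyond the scatter.

The compounds shown leave open whether a benzyl or a methoxy group at the same place would give a similar number, so the part played by the linking oxygen remains unsettled. Also open, going by these compounds, is whether phenoxy would act alike at another place on that ring.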